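Homologating the aryl substituent on the shared core

The source may hold more compounds than are shown below. What is called first, only, known or untested is meant among the compounds shown, and "the series" means these compounds.

compound 1 `O=C(NO)c1cccc(OCc2ccc(-c3noc(-c4ccccc4)n3)cc2)c1` — > 100000 nM
compound 2 `O=C(NO)c1cccc(OCc2ccc(-c3noc(-c4cccc(F)c4)n3)cc2)c1` — > 100000 nM
compound 3 `O=C(NO)c1cccc(OCc2ccc(-c3noc(Cc4ccccc4)n3)cc2)c1` — 7830 nM

In an assay on isolated protein for inhibition of sphingomyelin phosphodiesterase (Homo sapiens), read by fluorescence, with a stated time of 30 min (a higher number here means a weaker inhibitor, a lower number a stronger inhibitor), compound 1 gives > 100000 nM, a limit of the assay rather than a number. Compound 2 likewise gives > 100000 nM, also a limit. Compounds 1 and 2 thus sit at the limit of > 100000 nM in this assay, at which 2 of the 3 values shown sit. Going by the values given here, compound 3 gives 7830 nM, the only number among the three. The steps of an at least 12-fold lower number from compound 1 to compound 3 (1.10 log units; beyond the scatter) and an at least 12-fold lower number from compound 2 to compound 3 (1.10 log units; beyond the scatter) are both large. Compound 4 `O=C(NO)c1cccc(OCc2ccc(-c3noc(CCc4ccccc4)n3)cc2)c1` carries benzyl in place of phenyl on a saturated chain carbon bound to an aromatic carbon. Among the compounds with values here, no measured step tests this change itself; both measured steps replaced phenyl by benzyl and lowered the number strongly, so a further modest lowering, or none beyond the scatter, is expected: a 1.6-fold lower number from compound 3 to compound 4 (0.19 log units; within the scatter). For compound 4 the estimated value is 5000 nM, between 1500 nM and 20000 nM.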

Compound 4, half-maximal inhibitory concentration: 1730 nM
For compound 4 the middle estimate is 2.9-fold (0.46 log units) above the measured one; the range from low to high includes it.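

Going from benzyl to phenethyl still lowers the number in this assay: there is a 4.5-fold lower number from compound 3 to compound 4 (0.66 log units; beyond the scatter), so the gain seen on leaving the directly attached aryl rings does not end at benzyl. Against those aryl compounds the gap widens, with an at least 57-fold lower number from compound 1 to compound 4 (1.76 log units; beyond the scatter) and an at least 57-fold lower number from compound 2 to compound 4 (1.76 log units; beyond the scatter). Both of these steps start from a limit of the assay: the limit of > 100000 nM in this assay, at which 2 of the 4 values shown sit.

As far as these compounds go, whether a chain longer than phenethyl lowers the number further or reverses the trend remains open. So does the effect of an ether oxygen or an amine within the chain, or of fluoro on the phenethyl ring.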